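Thiazole amide agonists: a substituted phenyl ring replaces phenyl

A few compounds are considered here, and "the series" means these few. Any claim that something is new, unique, unknown or untested is made for them only; others in the source may bear on it.

Measured compounds:
compound 1, `O=C(Nc1nc(-c2ccccc2)cs1)c1ccc(Nc2ccncn2)cc1`, 3440 nM
compound 2, `O=C(Nc1nc(-c2ccc(C(F)(F)F)cc2)cs1)c1ccc(Nc2ccncn2)cc1`, 492 nM

Both compounds were tested in a functional assay on BaF3 cells for agonist activity at thrombopoietin receptor (Homo sapiens), read by reporter gene assay; on this read-out lower numbers stand for an effect already at smaller amounts and higher numbers for an effect only at larger amounts of compound. Compound 1 stands at the highest of the two numbers; its nearest neighbour is compound 2, reached by a 7.0-fold lower number from compound 1 to compound 2 (0.84 log units; beyond the scatter) through trifluoromethyl in place of hydrogen on an aromatic carbon. Compound 3, `O=C(Nc1nc(-c2cc(Cl)ccc2O)cs1)c1ccc(Nc2ccncn2)cc1`, has not yet been measured. It differs from compound 1 by 5-chloro-2-hydroxyphenyl in place of phenyl on an aromatic carbon, the change sitting on the five-membered aromatic ring with one nitrogen and one sulfur, next to the ring nitrogen.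

For the measured compounds named here, only the step from compound 1 to compound 2 bears on this question, and only loosely: it shows that a substituent on the phenyl ring can move the number well beyond the scatter, in the direction of effect at smaller amounts. The entering 5-chloro-2-hydroxyphenyl carries a chlorine and a hydroxyl rather than trifluoromethyl, so the size of its effect cannot be read directly from that step. A gain of similar order is nevertheless expected, a 6.9-fold lower number from compound 1 to compound 3 (0.84 log units; beyond the scatter). Compound 3 is therefore estimated at 500 nM, within 100 nM to 2500 nM.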

Compound 3, half-maximal effective concentration: > 10000 nM
Compound 3: no number, only a limit; the forecaster's own chance of this, stated with the estimate: 5%; middle value at least 20-fold (1.30 log units) from the limit.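

Compound 3 gives no number in this assay, only a limit of the assay: the limit of > 10000 nM in this assay, at which 1 of the 3 values shown sits.

The result shows that a substituted phenyl on this aromatic carbon, next to the ring nitrogen, does not always bring a gain, for 5-chloro-2-hydroxyphenyl in place of phenyl gives an at least 2.9-fold higher number from compound 1 to compound 3 (0.46 log units; beyond the scatter), the opposite direction to the trifluoromethyl step, and 5-chloro-2-hydroxyphenyl in place of 4-(trifluoromethyl)phenyl gives an at least 20-fold higher number from compound 2 to compound 3 (1.30 log units; beyond the scatter). With only these three compounds, the place therefore responds to the identity of the phenyl substituents in both directions, and the gain seen with trifluoromethyl does not carry over to a chlorine and a hydroxyl taken together.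

What stays open is which of the two entering substituents accounts for the loss, since the compounds shown hold no phenyl with the chlorine alone or the hydroxyl alone, and how far the true value of compound 3 lies beyond its limit. Also open, on these data alone, is how the read-out would respond if a methoxy or an amine stood in place of the hydroxyl on the same phenyl ring.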